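The source may hold more compounds than are shown below. What is called first, only, known or untested is meant among the compounds shown, and "the series" means these compounds.

The series shares one core, seen in compound 1 `CCNc1nnc(-c2cc(-c3ccc(F)cc3F)ccc2O)s1`, compound 2 `Cc1ccc(Nc2nnc(-c3cc(-c4ccc(F)cc4F)ccc3O)s2)cc1` and compound 3 `CNc1nnc(-c2cc(-c3ccc(F)cc3F)ccc2O)s1`, and varies only in the group carried on a nitrogen on an aromatic ring. In a functional assay on the whole organism (strain BALB/c) for inhibition, with Mus musculus as the target, read by paw edema, with a stated time of 4 h, at a dose of 50 mg/kg by the oral route (on this read-out lower numbers stand for less inhibition and higher numbers for more inhibition at the one dose given (going by the name of the read-out)), compound 1 gives 50.2%. In this assay compound 2 gives 43.5%, and compound 3 gives 45.4%. All three numbers lie within the scatter of one another: a number 6.7 percentage points lower from compound 1 to compound 2 (within the scatter), a number 4.8 percentage points lower from compound 1 to compound 3 (within the scatter) and a number 1.9 percentage points higher from compound 2 to compound 3 (within the scatter). Compound 3 thus stands second highest of the three, nearest to compound 2 and furthest from compound 1, with neither gap beyond the scatter.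

Compound 4 `COc1ccc(Nc2nnc(-c3cc(-c4ccc(F)cc4F)ccc3O)s2)cc1` has not yet been measured in this assay. The change from compound 3 is 4-methoxyphenyl in place of methyl on a nitrogen on an aromatic ring. For the measured compounds named here, two measured steps bear on it: a number 1.9 percentage points higher from compound 2 to compound 3 (within the scatter) is the reverse of a closely related exchange on the same nitrogen, and a number 6.7 percentage points lower from compound 1 to compound 2 (within the scatter) puts 4-methylphenyl in place of ethyl there; both are within the scatter. No step beyond the scatter is therefore expected in this assay, in either direction. Compound 4 is estimated at 44%, with a range from 34% to 54%. The expected step is a number 1.4 percentage points lower from compound 3 to compound 4 (within the scatter), anticipated to stay within the scatter.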

Compound 4, a percentage reported as inhibition, in the whole organism at one dose (the size of the read-out at that dose, not a potency): 55.3%
Beside the measured number, compound 4's estimate is 11.3 percentage points below it; the measured number lies above the stated range.
By their numbers in this assay, from the lowest: compounds 2, 3, 1 and 4 (each within the scatter of the next, the first and the last beyond it).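

In this assay, for the compounds shown here, the only step so far beyond the scatter is the exchange of methoxy in place of methyl on an aromatic carbon (a number 11.8 percentage points higher from compound 2 to compound 4 (beyond the scatter)), so this read-out does respond to a change within the aromatic group on the nitrogen, though the step is modest. Exchanges made directly on the nitrogen on an aromatic ring remain within the scatter, both against methyl (a number 9.9 percentage points higher from compound 3 to compound 4 (within the scatter)) and against ethyl (a number 5.1 percentage points higher from compound 1 to compound 4 (within the scatter)), so 4-methoxyphenyl is not separated from either small alkyl group, and the aromatic group as such brings no separation: 4-methylphenyl falls on one side of the two alkyl compounds and 4-methoxyphenyl on the other. The data shown include nothing that accounts for the step from methyl to methoxy.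

Open, going by these compounds, is whether the separation extends to other groups in place of the methoxy, such as a chloro, a hydroxy or a dimethylamino group. Also open is how the nitrogen responds to a longer chain such as butyl, or to a benzyl group, and only one dose and one time point are available for reading any of these compounds.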